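The compounds below may be only part of what the source reports. "The series", "measured", "known", "first", "only" and "open" are said of these compounds alone.

Compound 3 `COc1ccccc1CNC(=O)c1nn(-c2ccc(F)cc2)c(OC[C@@H](O)C[C@@H](O)CC(=O)O)c1C(C)C` gives 22 nM in an assay on microsomes from liver for inhibition of 3-hydroxy-3-methylglutaryl-coenzyme A reductase (Rattus norvegicus) (on this read-out higher numbers stand for weaker inhibition and lower numbers for stronger inhibition), the highest of the three numbers. Its nearest neighbour is compound 2 `COc1ccc(CNC(=O)c2nn(-c3ccc(F)cc3)c(OC[C@@H](O)C[C@@H](O)CC(=O)O)c2C(C)C)cc1`, which gives 12 nM; that gap, a 1.8-fold higher number from compound 2 to compound 3 (0.26 log units; within the scatter), lies within the scatter. Compound 1 `CC(C)c1c(C(=O)NCc2ccccc2)nn(-c2ccc(F)cc2)c1OC[C@@H](O)C[C@@H](O)CC(=O)O` gives 3.8 nM, and the two methoxy steps, a 3.2-fold higher number from compound 1 to compound 2 (0.50 log units; beyond the scatter) and a 5.8-fold higher number from compound 1 to compound 3 (0.76 log units; beyond the scatter), both lie beyond the scatter. Compound 4 `CC(C)c1c(C(=O)N(C)[C@H](C)c2ccccc2)nn(-c2ccc(F)cc2)c1OC[C@@H](O)C[C@@H](O)CC(=O)O` carries a different amide: methyl(1-phenylethyl)amino in place of (2-methoxybenzyl)amino on a carbonyl carbon. Of this change, only the loss of the methoxy has a measured counterpart, a 5.8-fold higher number from compound 1 to compound 3 (0.76 log units; beyond the scatter), which argues toward a lower number; the methyl on the nitrogen and the methyl within the 1-phenylethyl group have none. Compound 4 is therefore expected to show a 2.4-fold lower number from compound 3 to compound 4 (0.39 log units; beyond the scatter), with wide uncertainty. The estimate for compound 4 is 9 nM, between 2.5 nM and 35 nM.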

Compound 4, half-maximal inhibitory concentration: 21 nM
The estimate for compound 4 lay 2.3-fold (0.37 log units) below the measured number; the range from low to high includes it.
By their numbers in this assay, from the lowest: compound 1; then compounds 2, 4 and 3 (each within the scatter of the next).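

Compound 4 has no amide hydrogen and carries methyl(1-phenylethyl)amino on the carbonyl carbon, yet it stays level with both methoxybenzyl amides (a 1.0-fold lower number from compound 3 to compound 4 (0.02 log units; within the scatter); a 1.8-fold higher number from compound 2 to compound 4 (0.24 log units; within the scatter)). Only the benzylamino amide remains clearly apart (a 5.5-fold higher number from compound 1 to compound 4 (0.74 log units; beyond the scatter)), so at this position the amide hydrogen is not required for a number close to those of compounds 2 and 3. The compounds shown leave open how much each added methyl contributes, which a benzyl(methyl)amino or a plain 1-phenylethylamino amide would separate, and how the opposite 1-phenylethyl stereoisomer would read. No evidence here bears on the reason for this result.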